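Thiophen-3-yl in place of 4-iodophenyl on the aminothiophene core

The compounds below may be only part of what the source reports. "The series", "measured", "known", "first", "only" and "open" are said of these compounds alone.

Measured compounds:
compound 1 `COc1cc(C(=O)c2sc(-c3ccc(Cl)cc3)cc2N)cc(OC)c1OC` — 93 nM
compound 2 `COc1cc(C(=O)c2sc(-c3ccc(I)cc3)cc2N)cc(OC)c1OC` — 400 nM
compound 3 `COc1cc(C(=O)c2sc(-c3ccccc3)cc2N)cc(OC)c1OC` — 11 nM

Three compounds share a trimethoxybenzoyl–aminothiophene core and differ only in the aryl group attached to the ring carbon beside the sulfur. In a functional assay on L1210 cells (Mus musculus) for antiproliferative activity (on this read-out lower numbers stand for stronger inhibition and higher numbers for weaker inhibition), compound 2 gives 400 nM, the highest number of the three: compound 1 sits below it by a 4.3-fold higher number from compound 1 to compound 2 (0.63 log units; beyond the scatter) read in reverse, and compound 3 is furthest, with a 36-fold lower number from compound 2 to compound 3 (1.56 log units; beyond the scatter). Compound 1, in turn, lies above compound 3 by an 8.5-fold lower number from compound 1 to compound 3 (0.93 log units; beyond the scatter).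

Compound 4 `COc1cc(C(=O)c2sc(-c3ccsc3)cc2N)cc(OC)c1OC` has not yet been measured. It differs from compound 2 by thiophen-3-yl in place of 4-iodophenyl on an aromatic carbon. The measured steps show that every heavier halogen at the para position of the phenyl ring raised the number, and that the unsubstituted phenyl of compound 3 gave the lowest value. Among the compounds with values here, compound 4 carries no halogen at all and exchanges the phenyl for a thiophen-3-yl ring; no measured pair shows that exchange, so its effect is unknown. The strongest guide is compound 3 with 11 nM.

Compound 4 is therefore expected to move well below compound 2, by about a 16-fold lower number from compound 2 to compound 4 (1.20 log units; beyond the scatter), toward the region of compound 3. The estimate for compound 4 is 25 nM, with a likely range from 6 nM to 100 nM.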

Compound 4, half-maximal inhibitory concentration: 12 nM
Estimate against measurement, compound 4: 2.1-fold (0.32 log units) above, within the range that was stated.
By their numbers in this assay, from the lowest: compounds 3 and 4 (each within the scatter of the next); then compound 1; then compound 2.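

In this assay, changing the ring itself at this position, on the aromatic carbon next to the ring sulfur, makes no difference that the assay can resolve: the step is a 1.1-fold higher number from compound 3 to compound 4 (0.04 log units; within the scatter). The earlier compounds shown here varied only the group on a phenyl ring, whereas this result shows that a five-membered aromatic ring with 1 sulfur and the unsubstituted phenyl of compound 3 cannot be told apart here. The large steps of a 33-fold lower number from compound 2 to compound 4 (1.52 log units; beyond the scatter) and a 7.8-fold lower number from compound 1 to compound 4 (0.89 log units; beyond the scatter) place both halogen-bearing compounds at higher numbers than either unsubstituted ring, but nothing shown here explains why the two rings read alike or why the halogens raise the number.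

The compounds shown leave open whether a chloro group on the thiophen-3-yl ring would raise the number as it does on the phenyl ring of compound 1. They also leave open how thiophen-2-yl, pyridin-3-yl, or a phenyl ring carrying 4-fluoro or 4-methoxy would read at this position.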